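Swapping the chloroethenyl arm of compound 1 for iodine

A few compounds are considered here, and "the series" means these few. Any claim that something is new, unique, unknown or untested is made for them only; others in the source may bear on it.

Measured so far in a functional assay on CCRF-HSB-2 cells (Homo sapiens) for antiproliferative activity; on this read-out higher numbers stand for weaker inhibition and lower numbers for stronger inhibition:
- compound 1, `O=c1[nH]c(=O)n([C@H]2S[C@H](CO)[C@@H](O)[C@@H]2O)cc1/C=C/Cl`: > 100 ug/mL
- compound 2, `O=c1[nH]c(=O)n([C@@H]2S[C@H](CO)[C@@H](O)[C@@H]2O)cc1/C=C/Cl`: > 100 ug/mL
- compound 3, `Nc1ncnc2c1ncn2[C@@H]1S[C@H](CO)[C@@H](O)[C@@H]1O`: 14.8 ug/mL

Compound 1 gives > 100 ug/mL in this assay, which is a limit of the assay rather than a number. Compound 2 likewise gives > 100 ug/mL, again a limit. Compound 3 gives 14.8 ug/mL in this assay. For the measured compounds named here, the only step between measured compounds runs a step that the two limits leave unreadable from compound 1 to compound 2, and because of the limit of > 100 ug/mL in this assay, at which 2 of the 3 values shown sit, its size cannot be read. Since (the fact that compounds 1 and 2 differ only in the configuration as drawn), that step also tells nothing about changing a group on the aromatic ring.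

Compound 4, `O=c1[nH]c(=O)n([C@H]2S[C@H](CO)[C@@H](O)[C@@H]2O)cc1I`, differs from compound 1 as follows: iodo in place of 2-chloroethenyl on an aromatic carbon. Going by the values given here, no measured step bears on this exchange, so the expectation rests on where compound 1 stands. Compound 1 sits at the limit, so any movement that keeps compound 4 at or near that limit cannot be sized. For compound 4 in this assay a value of 100 ug/mL is estimated, with a range from 25 ug/mL to 400 ug/mL. This estimate means an expected step of a number no higher from compound 1 to compound 4 (the limit leaves the size open), with a fair chance that this assay again reports only a limit.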

Compound 4, half-maximal inhibitory concentration: > 100 ug/mL
Compound 4 gave a limit, no number (the forecaster's own chance of this, stated with the estimate: 65%); the middle value lies on the limit itself.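

No new step can be read, since compound 1 and compound 4 both give a limit rather than a number, leaving the exchange of 2-chloroethenyl for iodo without a size: the limit of > 100 ug/mL in this assay, at which 3 of the 4 values shown sit.

The compounds shown leave open whether any other group on that aromatic carbon would give a measurable value in this assay.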